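The source may hold more compounds than are shown below. What is called first, only, known or untested is meant among the compounds shown, and "the series" means these compounds.

Working notes on the series. Compound 1 `CCCSc1nc(N/N=C(\C)c2ccccc2O)c2nnn(Cc3ccco3)c2n1` carries a propylsulfanyl group and a hydrazone arm; in an ADME assay on GES1 cells (Homo sapiens) for antiproliferative activity, read by MTT assay, with a stated time of 72 h (on this read-out higher numbers stand for weaker inhibition and lower numbers for stronger inhibition), compound 1 gives 33300 nM. Compound 2 `CCCSc1nc(N/N=C/c2cc(OC)c(OC)c(OC)c2)c2nnn(Cc3ccccc3)c2n1` keeps the propylsulfanyl group and the shared core with a different hydrazone arm. In this assay compound 2 returns only a limit, not a number, namely > 64000 nM; this is the limit of > 64000 nM in this assay, at which 1 of the 2 values shown sits. Of the two values shown, compound 2 thus stands at the weak end, and only compound 1 gives a number.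

Compound 3 `COc1cc(/C=N/Nc2nc(SCc3ccccc3)nc3c2nnn3Cc2ccccc2)cc(OC)c1OC` is not yet measured in this assay. It differs from compound 2 by phenyl in place of ethyl on a saturated chain carbon bound to a sulfur. Among the compounds with values here, no step between two measured compounds is available to calibrate what this exchange does, so the starting point is the limit of compound 2 and the number of compound 1, with nothing beyond the scatter expected. The expected step is an at least 1.0-fold lower number from compound 2 to compound 3 (0.02 log units; that floor lies within the scatter), that is, within the scatter, with a real chance that this assay again reports only a limit. For compound 3 the estimate is 60000 nM, within 20000 nM to 180000 nM.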

Compound 3, half-maximal inhibitory concentration: 48300 nM
For compound 3 the middle estimate is 1.2-fold (0.09 log units) above the measured one; the range from low to high includes it.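

Within the data shown here, with the hydrazone arm and the shared core held constant, phenyl in place of ethyl on a saturated chain carbon bound to a sulfur gives an at least 1.3-fold lower number from compound 2 to compound 3 (0.12 log units; that floor lies within the scatter), the first step at this position in this assay. Compound 3 returns a number, 48300 nM, so the change from propylsulfanyl to benzylsulfanyl yields a measured value in this series. Compound 2 gave only a limit of the assay. The step has only a floor, and its true size cannot be fixed because compound 2 has no number: the limit of > 64000 nM in this assay, at which 1 of the 3 values shown sits.

Whether the real gap between compound 2 and compound 3 goes beyond the scatter stays unresolved, and compound 1 differs from compound 3 in more than one place, so it offers no clean comparison for this change. What an amine, a carboxylic acid or a longer chain such as hexyl would do on this sulfur-bound chain remains open in the compounds shown, as does whether benzylsulfanyl would have the same effect with another hydrazone arm.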